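Bromopyridine in Place of Bromophenyl on the Sulfonamide

The source may report more compounds than this note shows. Statements on the series, on what has been measured and on what is new or still open speak of the compounds shown alone.

Measured compounds:
compound 1 `CC1CCN(C2CCN(S(=O)(=O)c3cccc(N)c3)CC2)CC1` gives 3400 nM
compound 2 `CC1CCN(C2CCN(S(=O)(=O)c3cnc(Cl)s3)CC2)CC1` gives 1800 nM
compound 3 `CC1CCN(C2CCN(S(=O)(=O)c3cccc(Br)c3)CC2)CC1` gives 3.2 nM

These three compounds share a core and differ only in the aromatic group attached to the sulfonyl sulfur. They were tested in a functional assay on DLD-1 cells (Homo sapiens) for antiproliferative activity, read by CellTiter-Glo, with a stated time of 72 h; on this read-out lower numbers stand for stronger inhibition and higher numbers for weaker inhibition. Compound 3 gives the lowest number of the three: the step of a 560-fold lower number from compound 2 to compound 3 (2.75 log units; beyond the scatter) is large, and the step of a 1100-fold lower number from compound 1 to compound 3 (3.03 log units; beyond the scatter) is larger still, so compound 3 stands clearly apart from both others. By contrast, the step of a 1.9-fold lower number from compound 1 to compound 2 (0.28 log units; within the scatter) is within the scatter.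

Compound 4 `CC1CCN(C2CCN(S(=O)(=O)c3cncc(Br)c3)CC2)CC1` is not yet measured. Its change from compound 3 is 5-bromopyridin-3-yl in place of 3-bromophenyl on a sulfonyl sulfur. The bromine and the six-membered ring are kept; one ring carbon becomes a nitrogen.

For the measured compounds named here, no measured pair makes exactly this kind of swap. Going by the values given here, the steps that bear on it are those ending at compound 3, which show that the group on the sulfonyl sulfur controls activity strongly, and that the bromophenyl variant is the one giving the low number. Since compound 4 keeps the bromine, the expectation is a number near that of compound 3, perhaps somewhat higher, as the estimated step of a 3.1-fold higher number from compound 3 to compound 4 (0.49 log units; beyond the scatter) expresses. Compound 4 is therefore expected to give about 10 nM, in the range 2 nM to 60 nM.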

Compound 4, half-maximal inhibitory concentration: > 5000 nM
Compound 4 was reported as a limit; the forecaster's own chance of this, stated with the estimate: 2%; at least 500-fold (2.69 log units) between middle value and limit.
By their numbers in this assay, from the lowest: compound 3; then compounds 2 and 1 (each within the scatter of the next). At a limit, above all of these: compound 4.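

Compound 3 had suggested that the bromine might be what sets a group on the sulfonyl sulfur apart, but in this assay the bromine and the six-membered ring are both kept and a single ring carbon becoming a nitrogen gives an at least 1500-fold higher number from compound 3 to compound 4 (3.19 log units; beyond the scatter), so the bromine alone does not secure the low number. The value of compound 4 is a limit and not a number: the limit of > 5000 nM in this assay, at which 1 of the 4 values shown sits. Compound 4 also separates from the thiazole-bearing compound in an at least 2.7-fold higher number from compound 2 to compound 4 (0.44 log units; beyond the scatter), whereas an at least 1.4-fold higher number from compound 1 to compound 4 (0.16 log units; that floor lies within the scatter) cannot be read as a real difference, so its order relative to the aminophenyl compound stays undecided.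

The compounds shown give no reason why this one change in the ring has so large an effect. A chlorine or a methoxy group in place of the bromine on the phenyl ring would show whether the bromine itself is needed, or whether the all-carbon ring is what matters most at this place.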